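The source may hold more compounds than are shown below. What is called first, only, known or untested is meant among the compounds shown, and "the series" means these compounds.

Measured so far in an assay on cells for inhibition of Polyunsaturated fatty acid 5-lipoxygenase (Homo sapiens), read by HPLC, with a stated time of 15 min; on this read-out lower numbers stand for stronger inhibition and higher numbers for weaker inhibition:
- compound 1, `CCOC(=O)c1c(CSc2cccc(Cl)c2)n(C)c2ccc(O)cc12`: > 10000 nM, a limit of the assay and not a number
- compound 2, `CCOC(=O)c1c(CSc2ccc(F)cc2F)n(C)c2ccc(O)cc12`: 6800 nM

Going by the values given here, compound 2 therefore holds the only number in this assay; the other value is a limit. Among the compounds with values here, the single measured step, an at least 1.4-fold lower number from compound 1 to compound 2 (0.16 log units; that floor lies within the scatter), rests on that limit, (the limit of > 10000 nM in this assay, at which 1 of the 2 values shown sits), and so gives only a floor that sits within the scatter; it fixes no direction for changes of the group on the sulfur.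

Compound 3, `CCOC(=O)c1c(CSc2c(C)cccc2C)n(C)c2ccc(O)cc12`, differs from compound 2 in one place: 2,6-dimethylphenyl in place of 2,4-difluorophenyl on a sulfur. Within the data shown here, no measured step matches this change, and the one step available is too small to set a direction. In this assay no step beyond the scatter is expected either way, though the limit on compound 1 leaves room for a weaker result. The value expected for compound 3 is 7000 nM, within 2000 nM to 30000 nM. The step expected is a 1.0-fold higher number from compound 2 to compound 3 (0.01 log units; within the scatter).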

Compound 3, half-maximal inhibitory concentration: 1200 nM
The estimate for compound 3 lay 5.8-fold (0.77 log units) above the measured number, and the stated range ends above it.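

On the group carried by the sulfur, this assay now gives a step beyond the scatter: a 5.7-fold lower number from compound 2 to compound 3 (0.75 log units; beyond the scatter). This step comes with 2,6-dimethylphenyl in place of 2,4-difluorophenyl, two groups that match in heavy-atom count, in their one six-membered aromatic ring of carbon only and in carrying no hydrogen-bond donors or acceptors, so the group on the sulfur can move the number even where these counts stay the same. The change from 3-chlorophenyl also clears the scatter, an at least 8.3-fold lower number from compound 1 to compound 3 (0.92 log units; beyond the scatter), but that is only a floor, and compound 1 stands at a limit of the assay, not a number: the limit of > 10000 nM in this assay, at which 1 of the 3 values shown sits.

The compounds shown do not tell whether the methyl groups or the absence of halogen goes with the lower number. On these data alone, a plain phenyl or a cyclohexyl on the sulfur remains open.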